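The compounds below may be only part of what the source reports. "The series", "measured", "known", "first", "only" and "open" are said of these compounds alone.

Measured in an ADME assay on the whole organism (plasma, Mus musculus, strain CD1), read by LC-MS, with a stated time of 24 h; on this read-out lower numbers stand for a smaller free fraction and higher numbers for a larger free fraction
- compound 1 `O=C(O)Cn1nc(Cc2nc3cc(Cl)c(OCC(F)F)cc3[nH]2)c2ccccc2c1=O` gives 0.038
- compound 2 `O=C(O)Cn1nc(Cn2cc3cc(OCC4CC4)c(Cl)cc3n2)c2ccccc2c1=O` gives 0.01
- compound 3 `C[C@H](C(=O)O)n1nc(Cn2cc3cc(OCC4CC4)c(Cl)cc3n2)c2ccccc2c1=O` gives 0.011

Compound 1 stands highest of the three, beyond the scatter from both others. Compound 4 `O=C(O)Cn1nc(Cc2nc3cc(Cl)c(OCC4CC4)cc3[nH]2)c2ccccc2c1=O` keeps the core of compound 1 and makes one change: cyclopropyl in place of difluoromethyl on a saturated chain carbon bound to an oxygen on an aromatic ring, that is, 2,2-difluoroethyl to cyclopropylmethyl. Going by the values given here, no measured step covers this change. The one available, a 1.1-fold higher number from compound 2 to compound 3 (0.04 log units; within the scatter), lies elsewhere and does not bear on it. Compound 2 and compound 3 carry cyclopropylmethoxy on another core, and both values lie under that of compound 1. A downward step is therefore expected, with low confidence, and the expected size is a 2.1-fold lower number from compound 1 to compound 4 (0.32 log units; beyond the scatter) here. Compound 4 is estimated at 0.018 in this assay, within 0.009 to 0.036 as the expected range.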

Compound 4, unbound fraction: 0.012
Compound 4: the middle estimate sits 1.5-fold (0.18 log units) above what was measured, and the stated range covers the measured number.
By their numbers in this assay, from the lowest: compounds 2, 3 and 4 (each within the scatter of the next); then compound 1.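

In this assay the change from 2,2-difluoroethoxy to cyclopropylmethoxy gives a 3.2-fold lower number from compound 1 to compound 4 (0.50 log units; beyond the scatter) on the core of compound 1, the first step read at this position. Going by these compounds alone, the only earlier step lay on a saturated chain carbon bound to an aromatic nitrogen and a carbonyl carbon, so this is the first sign that the free fraction responds on the chain carbon bound to an oxygen on an aromatic ring. Nothing measured here accounts for the step.

Open, from the compounds shown here alone, is how a trifluoromethyl group, a longer chain or an amine would read at this position. Also open, going by these compounds, is whether the step carries over to the core of compound 2.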